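One Hydroxy Group Fewer on Compound 2

The source may hold more compounds than are shown below. What is called first, only, known or untested is meant among the compounds shown, and "the series" means these compounds.

Measured in an ADME assay on MDCK cells (Canis lupus familiaris) for cytotoxicity; a lower number here means that less compound is tolerated, a higher number that more compound is tolerated:
- compound 1 `O=[N+]([O-])C1=CNc2nc(C(F)(F)F)nn2C1O`: 33000 nM
- compound 2 `O=[N+]([O-])C1=CNc2nc(C(F)(F)F)nn2C1c1ccc(O)c(O)c1O`: 373000 nM

Of these two, compound 2 stands highest at 373000 nM. Compound 1 gives 33000 nM. The gap between these two compounds lies beyond the scatter. Compound 3 `O=[N+]([O-])C1=CNc2nc(C(F)(F)F)nn2C1c1ccc(O)cc1O` has hydrogen in place of hydroxy on an aromatic carbon. Going by the values given here, no measured pair isolates this change, so the expectation is tentative: a small move towards a lower number in this assay, perhaps none beyond the scatter. The expected step is a 1.5-fold lower number from compound 2 to compound 3 (0.17 log units; within the scatter). For compound 3 the estimated value is 250000 nM, with an expected range from 80000 nM to 600000 nM.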

Compound 3, half-maximal cytotoxic concentration: 258000 nM
The estimate for compound 3 lay 1.0-fold (0.01 log units) below the measured number; measured number inside the range.
By their numbers in this assay, from the lowest: compound 1; then compounds 3 and 2 (each within the scatter of the next).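

In this assay, hydrogen in place of hydroxy on the aromatic carbon ortho to two hydroxy groups gives a 1.4-fold lower number from compound 2 to compound 3 (0.16 log units; within the scatter) and so leaves the number within the scatter of compound 2. The 2,4-dihydroxyphenyl group in place of hydroxy on the saturated ring carbon still gives a 7.8-fold higher number from compound 1 to compound 3 (0.89 log units; beyond the scatter) and so keeps a gap to compound 1 without the third hydroxy group. On these data alone, what a methoxy group, an amine or fluorine would give on this aromatic carbon remains open, as does a plain phenyl group with no hydroxy. Nothing further is available to explain these numbers.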